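Isopropylcarbonyl to propanoyl on the shared core

The source may hold more compounds than are shown below. What is called first, only, known or untested is meant among the compounds shown, and "the series" means these compounds.

Of the compounds shown here, three have been measured in an assay on HEK293 cells for positive allosteric modulation of metabotropic glutamate receptor 2 (Rattus norvegicus), read by thallium flux, with a stated time of 2.5 min; a lower number here means a smaller maximal response, a higher number a larger maximal response. Compound 1 `CCC(=O)c1ccc(OCCCCOc2cc(C(=O)O)ccc2OC)c(C)c1O` gives 72.6%. Compound 2 `COc1ccc(C(=O)O)cc1OCCCCOc1ccc(C(=O)C(C)C)c(O)c1C` gives 66.6%. Compound 3 `Cc1cc(C(=O)O)ccc1OCCCCOc1ccc(C(=O)C(C)C)c(O)c1C` gives 76.9%. Compound 1 and compound 2 differ in one place, (hydrogen in place of methyl on a saturated chain carbon bound to a carbonyl carbon and a saturated chain carbon); the step of a number 6 percentage points higher from compound 2 to compound 1 (within the scatter). Compound 3 and compound 1 lie within the scatter of each other, while the value of compound 2 sits below that of compound 3 by more than the scatter. The difference between the core of compound 3 and the core of compound 2 is not broken down here.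

Compound 4 `CCC(=O)c1ccc(OCCCCOc2ccc(C(=O)O)cc2C)c(C)c1O` is not yet measured. It arises from compound 3 by hydrogen in place of methyl on a saturated chain carbon bound to a carbonyl carbon and a saturated chain carbon, the same change as from compound 2 to compound 1, at the same place. Among the measured compounds shown here, the step is expected to be small, a number 3.1 percentage points higher from compound 3 to compound 4 (within the scatter), because the earlier step of a number 6 percentage points higher from compound 2 to compound 1 (within the scatter) stayed within the scatter; only that one pair supports this. Compound 4 is therefore estimated at 80%, with a range from 68% to 92%.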

Compound 4, largest response reached (reported as percent of maximum), in percent of the reference or control that the assay uses: 86.6%
Beside the measured number, compound 4's estimate is 6.6 percentage points below it, within the range that was stated.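

In this assay the change from isopropylcarbonyl to propanoyl on the core of compound 3 gives a number 9.7 percentage points higher from compound 3 to compound 4 (within the scatter). Set beside the earlier step, the change carries from one core to the other with no difference that can be told apart: the same change on two cores in this assay, a number 6 percentage points higher (within the scatter) from compound 2 to compound 1 and a number 9.7 percentage points higher (within the scatter) from compound 3 to compound 4, 3.7 percentage points apart, within the scatter of two such steps. Each step lies within the scatter, however, so neither pair establishes a real gain in maximal response for propanoyl over isopropylcarbonyl, and two cores give no rule for the wider series.

Still open, on these data alone, is how the response behaves when the same carbonyl carries a methyl, as in acetyl, a longer chain, as in butanoyl, or a ring, as in cyclopropylcarbonyl. Also open, as far as these compounds go, is whether the change from isopropylcarbonyl to propanoyl carries over to cores where a tetrazole or an amide stands in place of the carboxylic acid, or where a longer chain links the two ends of the molecule.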